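Methoxy Added to the Benzamide of Compound 2

A few compounds are considered here, and "the series" means these few. Any claim that something is new, unique, unknown or untested is made for them only; others in the source may bear on it.

Compound 1, `CNC(=O)CSc1nc2ccc(NC(=O)c3ccccc3OC)cc2s1`, gives 23400 nM in a functional assay on MCF7 cells (Homo sapiens) for cytotoxicity, read by MTT assay, with a stated time of 48 h; on this read-out higher numbers stand for weaker inhibition and lower numbers for stronger inhibition.
Compound 2, `O=C(CSc1nc2ccc(NC(=O)c3ccccc3)cc2s1)NCc1ccccc1`, gives 35600 nM in this assay.

Only these two compounds have been measured, and they differ in two places, so no single step can be read from them. Compound 2 and compound 1 have numbers that lie within the usual scatter of each other, so neither can be set above the other.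

Compound 3, `COc1ccccc1C(=O)Nc1ccc2nc(SCC(=O)NCc3ccccc3)sc2c1`, is compound 2 with one change: methoxy in place of hydrogen on an aromatic carbon. The entering group sits on an aromatic carbon of a six-membered aromatic ring of carbon only, ortho to a large group. Compound 1 carries the same methoxy group together with a different amide, which gives a hint but no clean comparison.

For compound 3 the expectation is a small step, a 1.4-fold lower number from compound 2 to compound 3 (0.14 log units; within the scatter), not clearly beyond the scatter. Compound 3 is therefore estimated at 26000 nM, with a range from 10000 nM to 65000 nM.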

Compound 3, half-maximal inhibitory concentration: 17200 nM
Compound 3: middle estimate off by 1.5-fold (0.18 log units), on the high side; the measured number falls inside the stated range.
By their numbers in this assay, from the lowest: compounds 3, 1 and 2 (each within the scatter of the next, the first and the last beyond it).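

In this assay, among these compounds, methoxy in place of hydrogen on an aromatic carbon, ortho to a large group, gives a 2.1-fold lower number from compound 2 to compound 3 (0.32 log units; beyond the scatter) as the first single change that can be read here, a modest step that lies just beyond the scatter. With the methoxy group held in place, phenyl in place of hydrogen on a saturated chain carbon bound to an amide-type nitrogen gives a 1.4-fold lower number from compound 1 to compound 3 (0.13 log units; within the scatter) and stays within the scatter, so compound 1 and compound 3 cannot be told apart. Nothing measured here accounts for the methoxy step.

As far as these compounds go, whether an amine, a hydroxyl group or an ethoxy group in the same place would give a step of similar size remains open. Also open, from the compounds shown here alone, is the size of the methoxy step on the amide of compound 1.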